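This account rests on a few compounds, and the source may have more. Where it says the series, first, only, none or still open, it means among the compounds named here.

In a functional assay on MCF7 cells (Homo sapiens) for cytotoxicity, read by sulforhodamine B assay, with a stated time of 24 h (a higher number here means a weaker inhibitor, a lower number a stronger inhibitor), the measured compounds read as follows:

Compound 1 `O=C1Nc2ccc(S(=O)(=O)N3CCOCC3)cc2/C1=N/c1ccc(O)cc1` gives 52700 nM
Compound 2 `Cc1ccc(S(=O)(=O)N/N=C2\C(=O)Nc3ccc(S(=O)(=O)N4CCOCC4)cc32)cc1` gives 38400 nM
Compound 3 `CC(=O)N/N=C1\C(=O)Nc2ccc(S(=O)(=O)N3CCOCC3)cc21` gives 56000 nM

Compound 3 stands level with the other two, as a 1.1-fold higher number from compound 1 to compound 3 (0.03 log units; within the scatter) and a 1.5-fold higher number from compound 2 to compound 3 (0.16 log units; within the scatter) show. Compound 4 `N/N=C1\C(=O)Nc2ccc(S(=O)(=O)N3CCOCC3)cc21` carries hydrogen in place of acetyl on an amine nitrogen. Those two measured steps bear on this change, although neither ends in a bare hydrogen and neither left the scatter. No step beyond the scatter is therefore expected in this assay and no direction can be told. The estimate means a 1.2-fold lower number from compound 3 to compound 4 (0.07 log units; within the scatter) as the expected step. Compound 4 is expected at 48000 nM within an estimated range from 22000 nM to 100000 nM as its likely reading.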

Compound 4, half-maximal inhibitory concentration: 46800 nM
Compound 4: the middle estimate sits 1.0-fold (0.01 log units) above what was measured; low and high end bracket the measured number.
By their numbers in this assay, from the lowest: compounds 2, 4, 1 and 3 (each within the scatter of the next).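

In this assay, taking the substituent away altogether still gives no step beyond the scatter: hydrogen in place of acetyl on the amine nitrogen (a 1.2-fold lower number from compound 3 to compound 4 (0.08 log units; within the scatter)), hydrogen in place of (4-methylphenyl)sulfonyl (a 1.2-fold higher number from compound 2 to compound 4 (0.09 log units; within the scatter)), and amino in place of 4-hydroxyphenyl (a 1.1-fold lower number from compound 1 to compound 4 (0.05 log units; within the scatter)). This position therefore shows no measurable dependence on the group it carries, across these four compounds, even with no heavy atom there. Nothing measured explains this flat reading. As far as these compounds go, whether a carboxylic acid or a longer chain on this nitrogen would leave the scatter remains open.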